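Pyrazolyl in place of pyrimidinyl on the biaryl sulfonamide series

The compounds below may be only part of what the source reports. "The series", "measured", "known", "first", "only" and "open" are said of these compounds alone.

Measured compounds:
compound 1 `COc1ccc(F)c(-c2ccc(S(=O)(=O)Nc3cc(N4C[C@@H](C)N[C@@H](C)C4)ccc3OC)cc2)c1`, 1.2
compound 2 `COc1cccc(-c2ccc(S(=O)(=O)Nc3cc(N4C[C@@H](C)N[C@@H](C)C4)ccc3OC)cc2)c1`, 1
compound 3 `COc1ccc(N2C[C@@H](C)N[C@@H](C)C2)cc1NS(=O)(=O)c1ccc(-c2cncnc2)cc1`, 0.6

In a functional assay for agonist activity at growth hormone secretagogue receptor type 1 (Homo sapiens), read by FLIPR (on this read-out lower numbers stand for smaller maximal responses and higher numbers for larger maximal responses), compound 3 stands lowest of the three; compound 2 is nearest, and compound 1 furthest, both beyond the scatter. The two steps that reach compound 3 are large: a number 0.60 lower from compound 1 to compound 3 (beyond the scatter) and a number 0.40 lower from compound 2 to compound 3 (beyond the scatter), each exchanging a methoxy-bearing phenyl for pyrimidin-5-yl. Among the measured compounds shown here, the one change among the phenyl-bearing compounds is smaller, a number 0.20 lower from compound 1 to compound 2 (beyond the scatter).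

Compound 4 `COc1ccc(N2C[C@@H](C)N[C@@H](C)C2)cc1NS(=O)(=O)c1ccc(-n2cccn2)cc1` is not yet measured. The change from compound 3 is 1H-pyrazol-1-yl in place of pyrimidin-5-yl on an aromatic carbon. For the measured compounds named here, no measured step exchanges one such ring for another, so the direction of this step is not covered by the data. The measured steps show only that moving from a methoxyphenyl group to pyrimidin-5-yl lowers the maximal response; whether pyrazol-1-yl behaves like pyrimidin-5-yl or recovers part of the response is open. The expectation is a step of about no change at the digits printed from compound 3 to compound 4 (within the scatter), within or close to the scatter, with a range wide enough to allow a modest movement either way. For compound 4 the estimate in this assay is 0.6, between 0.4 and 0.85.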

Compound 4, intrinsic activity: the largest response reached, as a fraction of the reference agonist's: 0.8
Beside the measured number, compound 4's estimate is 0.20 below it; measured number inside the range.
By their numbers in this assay, from the lowest: compound 3; then compound 4; then compound 2; then compound 1.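

In this assay, the aromatic carbon para to a large group now shows an exchange of one two-hetero-atom ring for another, and the step is a number 0.20 higher from compound 3 to compound 4 (beyond the scatter), so the outcome at this position depends on which such ring is present, even though the entering and leaving rings match in hetero atoms, hydrogen-bond donors, hydrogen-bond acceptors and net charge. The 1H-pyrazol-1-yl ring, five-membered where pyrimidin-5-yl is six-membered, regains only part of the ground held by the methoxy-bearing phenyl groups, with steps of a number 0.20 lower from compound 2 to compound 4 (beyond the scatter) and a number 0.40 lower from compound 1 to compound 4 (beyond the scatter), so the order at this position across the four compounds is pyrimidin-5-yl, 1H-pyrazol-1-yl, 3-methoxyphenyl, 2-fluoro-5-methoxyphenyl. Nothing available explains the gain from this ring exchange.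

One pair cannot separate ring size from the attachment through ring nitrogen rather than ring carbon, and 1H-imidazol-1-yl or pyridin-3-yl at the same position would bear on that. Also open, as far as these compounds go, is whether methyl or chloro on the 1H-pyrazol-1-yl ring would carry the response further towards that of the methoxy-bearing phenyl compounds.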